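Methyl for isopropyl: carrying one measured step to compound 4

The compounds below may be only part of what the source reports. "The series", "measured", "known", "first", "only" and "open" are said of these compounds alone.

Measured so far in a functional assay on A549 cells (Homo sapiens) for cytotoxicity, read by MTT assay; on this read-out higher numbers stand for weaker inhibition and lower numbers for stronger inhibition:
compound 1 `CC(C)[C@@H](NC(=S)Nc1ccccc1)c1nc2ccccc2[nH]1` gives 31500 nM
compound 2 `CC(C)[C@@H](NC(=S)Nc1cc(C(F)(F)F)cc(C(F)(F)F)c1)c1nc2ccccc2[nH]1` gives 22400 nM
compound 3 `C[C@@H](NC(=S)Nc1ccccc1)c1nc2ccccc2[nH]1` gives 14800 nM

Compound 1 and compound 3 differ in one place only: methyl in place of isopropyl on a saturated chain carbon bound to an amide-type nitrogen and an aromatic carbon. That change gave a 2.1-fold lower number from compound 1 to compound 3 (0.33 log units; beyond the scatter), a single measured instance of it. Compound 2 and compound 1 differ by more than one place; the difference between the two cores is not broken down here. The value of compound 2 lies within the scatter of both compound 1 and compound 3, so nothing is read into its position among them.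

Compound 4 `C[C@@H](NC(=S)Nc1cc(C(F)(F)F)cc(C(F)(F)F)c1)c1nc2ccccc2[nH]1` has not been measured. It relates to compound 2 exactly as compound 3 relates to compound 1: methyl in place of isopropyl on a saturated chain carbon bound to an amide-type nitrogen and an aromatic carbon. The two place descriptions match word for word, so this is the same change, now on the core of compound 2.

Within the data shown here, the step from compound 2 to compound 4 is expected to be about a 2.1-fold lower number from compound 2 to compound 4 (0.32 log units; beyond the scatter) in this assay, because a 2.1-fold lower number from compound 1 to compound 3 (0.33 log units; beyond the scatter) is the only guide available and the core difference is not resolved. Compound 4 is therefore estimated at 10700 nM, with a likely range of 5000 nM to 25000 nM.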

Compound 4, half-maximal inhibitory concentration: 15200 nM
Compound 4: the middle estimate sits 1.4-fold (0.15 log units) below what was measured, within the range that was stated.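

In this assay, the exchange of isopropyl for methyl on the core of compound 2 comes out as a 1.5-fold lower number from compound 2 to compound 4 (0.17 log units; within the scatter), so this pair alone cannot establish an effect of the change. Set beside the earlier pair, it gives no sign that the core alters the outcome: the same change on two cores in this assay, a 2.1-fold lower number (0.33 log units; beyond the scatter) from compound 1 to compound 3 and a 1.5-fold lower number (0.17 log units; within the scatter) from compound 2 to compound 4, 1.4-fold (0.16 log units) apart, within the scatter of two such steps This shows that the two cores give compatible results for this change, but it does not show that the step has the same size on both, and two pairs, only one of them beyond the scatter, do not establish a general rule for the series.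

The compounds shown leave open what a longer chain, an amine or a carboxylic acid would do in place of isopropyl on the saturated chain carbon. They also leave open whether the change would carry over to a core with nitrile groups in place of the trifluoromethyl groups.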